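The source may hold more compounds than are shown below. What is called first, only, known or untested is meant among the compounds shown, and "the series" means these compounds.

Measured so far:
compound 1 `CN(C)CCCNc1nc(-c2ccc(NC(=O)Nc3ccccc3Cl)cc2)nc2ccsc12` — 430 nM
compound 2 `CCN(CC)CCCNc1nc(-c2ccc(NC(=O)Nc3ccccc3)cc2)nc2c(Cl)c(Cl)sc12` — 850 nM

Two compounds of the series have numbers in a functional assay on NCI-H460 cells (Homo sapiens) for cytotoxicity, read by MTT assay, with a stated time of 72 h; on this read-out lower numbers stand for stronger inhibition and higher numbers for weaker inhibition. Compound 1 gives 430 nM. Compound 2 carries a diethylamino-terminated chain and two chlorines on its core in place of the dimethylamino chain and unsubstituted core of compound 1, and a plain phenyl urea end instead of the 2-chlorophenyl urea. Compound 2 gives 850 nM. Compound 2 thus holds the higher of the two numbers, but the gap to compound 1 lies within the scatter, so the two values cannot be told apart on what is available. Going by the values given here, the pair differ in several places at once, and no single step can be drawn from it.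

Compound 3 `CCN(CC)CCCNc1nc(-c2ccc(NC(=O)Nc3ccc(C)cc3)cc2)nc2c(Cl)c(Cl)sc12` remains to be measured in this assay. It differs from compound 2 by methyl in place of hydrogen on an aromatic carbon, para to a large group. Nothing measured bears directly on this change. The expected step from compound 2 to compound 3 in this assay is a 1.1-fold lower number from compound 2 to compound 3 (0.03 log units; within the scatter), essentially none beyond the scatter. Compound 3 is therefore estimated at 800 nM, with a range of 300 nM to 2200 nM.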

Compound 3, half-maximal inhibitory concentration: 1240 nM
Beside the measured number, compound 3's estimate is 1.6-fold (0.19 log units) below it; measured number inside the range.
By their numbers in this assay, from the lowest: compounds 1, 2 and 3 (each within the scatter of the next, the first and the last beyond it).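

In this assay, the series now has its first comparison that differs in one place, and phenyl to 4-methylphenyl on the urea end gives a 1.5-fold higher number from compound 2 to compound 3 (0.16 log units; within the scatter) for methyl in place of hydrogen on an aromatic carbon. At this position, para to a large group, one added carbon therefore produces no difference that can be separated from the usual scatter, at least on the background of compound 2, with its diethylamino-terminated chain and two chlorines on the core. No accompanying measurement offers any explanation for this result.

Open, as far as these compounds go, is whether the position stays as undemanding for groups other than methyl, such as a methoxy group, a tert-butyl group, a carboxylic acid or a primary amine, since a single small substituent says little about the range of groups that could sit there. Also open, from the compounds shown here alone, is whether the same methyl change would read alike on the unsubstituted core and dimethylamino chain of compound 1, and how the chain, the core chlorines and the 2-chlorophenyl end each contribute, as compound 1 still differs from compound 2 and compound 3 in several places at once.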